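Chain shortening from compound 3 toward compound 4

The compounds below may be only part of what the source reports. "The series", "measured", "known", "first", "only" and "open" are said of these compounds alone.

Compound 3 `CCCCCCCCc1cn(C(c2ccccc2)c2cc3cc(Br)ccc3nc2OC)nn1` gives 2.27% in an ADME assay on PC-3 cells (Homo sapiens) for cytotoxicity, read by sulforhodamine B assay, with a stated time of 48 h, tested at 10 uM (on this read-out higher numbers stand for more inhibition at the one concentration tested (going by the name of the read-out) and lower numbers for less inhibition), and stands lowest of the three numbers measured. Compound 1 `CCCCCCCc1cn(C(c2ccccc2)c2cc3cc(Br)ccc3nc2OC)nn1` gives 4.42% in this assay, and compound 2 `COc1nc2ccc(Br)cc2cc1C(c1ccccc1)n1cc(-c2ccccc2F)nn1` gives 13.4%. The step of a number 2.2 percentage points lower from compound 1 to compound 3 (within the scatter) and the step of a number 11.1 percentage points lower from compound 2 to compound 3 (beyond the scatter) place compound 3 at the bottom, though only the gap to compound 2 is beyond the scatter; the gap to compound 1 is not.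

Compound 4 `CCCc1cn(C(c2ccccc2)c2cc3cc(Br)ccc3nc2OC)nn1` differs from compound 3 in one place: hydrogen in place of pentyl on a saturated chain carbon, three bonds along the chain from an aromatic carbon. Cut one bond further out, the same difference reads octyl to propyl.

Among the compounds with values here, two measured steps bear on this. Within the data shown here, the step of a number 2.2 percentage points lower from compound 1 to compound 3 (within the scatter) is the only measured change in chain length and is within the scatter. The step of a number 11.1 percentage points lower from compound 2 to compound 3 (beyond the scatter) exchanges the chain for an aromatic group and is modest. Among the measured compounds shown here, no measured step removes as much of the chain as this one does, so the expectation rests on the chain step alone, and the aromatic comparison only shows that the shared core reaches higher numbers with other substituents.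

In this assay a step no larger than the scatter is therefore expected, with a slight lean upward. Compound 4 is expected to give 5%, within a range of -5% to 15%. The expected step of a number 2.7 percentage points higher from compound 3 to compound 4 (within the scatter) stays within the scatter.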

Compound 4, a percentage reported as inhibition, at one concentration (the size of the read-out at that concentration, not a potency): 8.3%
The estimate for compound 4 lay 3.3 percentage points below the measured number; low and high end bracket the measured number.
By their numbers in this assay, from the lowest: compounds 3, 1, 4 and 2 (each within the scatter of the next, the first and the last beyond it).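

In this assay, hydrogen in place of pentyl, the largest cut in the chain seen so far, gives a number 6 percentage points higher from compound 3 to compound 4 (within the scatter), so even this much shortening on the chain does not carry the read-out past the scatter. Going from heptyl to propyl reads the same way, with a number 3.9 percentage points higher from compound 1 to compound 4 (within the scatter), so octyl, heptyl and propyl on this aromatic carbon cannot be told apart in this assay. The comparison with the 2-fluorophenyl group also changes with chain length: propyl in its place gives a number 5.1 percentage points lower from compound 2 to compound 4 (within the scatter), whereas octyl in its place gives a number 11.1 percentage points lower from compound 2 to compound 3 (beyond the scatter), so the one gap beyond the scatter at this aromatic carbon does not hold for the propyl chain.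

Open, on these data alone, is whether a methyl group, an amine or a carboxylic acid on this aromatic carbon would move the number beyond the scatter from that of compound 4, or whether the whole set stays this low at the one concentration tested. Nothing at hand explains the numbers of these compounds.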